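Compound 2 and a larger cyclic amine: an estimate

This account rests on a few compounds, and the source may have more. Where it says the series, first, only, none or still open, it means among the compounds named here.

Compound 1 `COc1cc2c(Oc3c(F)cc(NC(=O)NN4C(=O)C(C)SC4c4c(F)cccc4F)cc3F)ccnc2cc1OCCCN1CCCC1`: 670 nM
Compound 2 `COc1cc2c(Oc3c(F)cc(NC(=O)NN4C(=O)CCSC4c4c(F)cccc4F)cc3F)ccnc2cc1OCCCN1CCCC1`: 270 nM
Compound 3 `COc1cc2c(Oc3c(F)cc(NC(=O)NN4C(=O)CSC4c4c(F)cccc4F)cc3F)ccnc2cc1OCCCN1CCC(N2CCCCC2)CC1`: 280 nM

All three compounds were tested in a functional assay on HT-29 cells (Homo sapiens) for antiproliferative activity, read by MTT assay, with a stated time of 72 h; on this read-out lower numbers stand for stronger inhibition and higher numbers for weaker inhibition. Compound 2 gives the lowest of the three numbers, 270 nM. Compound 3 sits very close to it, and the gap between the two lies within the scatter of this kind of measurement, so no order between compound 2 and compound 3 can be claimed. Compound 1 is further away, and its gap to compound 2 lies beyond the scatter.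

Compound 4 `COc1cc2c(Oc3c(F)cc(NC(=O)NN4C(=O)CCSC4c4c(F)cccc4F)cc3F)ccnc2cc1OCCCN1C[C@H]2CCCC[C@H]2C1` has not been measured. It differs from compound 2 by a group of 9 heavy atoms (8 carbon, 1 nitrogen; one five-membered non-aromatic ring with 1 hetero atom, one six-membered non-aromatic ring of carbon only) in place of a group of 5 heavy atoms (4 carbon, 1 nitrogen; one five-membered non-aromatic ring with 1 hetero atom), on a saturated chain carbon, three bonds along the chain from an oxygen on an aromatic ring. Among the compounds measured so far there is no pair in which only this part of the molecule is changed, so the expectation rests on compound 2 alone. With no direct evidence on this change, no step beyond the scatter is expected in this assay, in either direction. The step of a 1.1-fold higher number from compound 2 to compound 4 (0.05 log units; within the scatter) is therefore expected to be small. Compound 4 is estimated at 300 nM, with a range from 130 nM to 700 nM.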

Compound 4, half-maximal inhibitory concentration: 790 nM
The estimate for compound 4 lay 2.6-fold (0.42 log units) below the measured number, outside the stated range (above it).
By their numbers in this assay, from the lowest: compounds 2 and 3 (each within the scatter of the next); then compounds 1 and 4 (each within the scatter of the next).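

This is the only pair shown in which nothing changes but the group on the saturated chain carbon, three bonds along the chain from an oxygen on an aromatic ring, and in this assay it gives a 2.9-fold higher number from compound 2 to compound 4 (0.47 log units; beyond the scatter). The position therefore responds to this exchange: replacing pyrrolidin-1-yl with the larger group, which retains a five-membered ring with its nitrogen and adds a six-membered ring of carbon only, moves the number towards weaker inhibition, even though both groups have the same hydrogen-bond donor and acceptor counts and no net charge. No measurement here bears on what lies behind this step.

On these data alone, whether the step follows the size of the amine stays open, as does the question of whether a piperidin-1-yl or a morpholin-4-yl group at this place would fall with compound 2 or with compound 4. Also open, as far as these compounds go, is what part the two defined stereocentres of the entering group play, and whether the added six-membered carbon ring would have the same effect with the opposite arrangement at those centres.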